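Tert-butyl for methoxymethyl on a core held at the limit

The source may hold more compounds than are shown below. What is called first, only, known or untested is meant among the compounds shown, and "the series" means these compounds.

Compound 1, `Cc1ncc2cnnc(O)n12`, in a functional assay for inhibition, with Homo sapiens as the target (a higher number here means a weaker inhibitor, a lower number a stronger inhibitor), gives > 48000 nM, which is a limit of the assay.
Compound 2, `Oc1nncc2cncn12`, in this assay gives > 48000 nM, also a limit.
Compound 3, `COCc1ncc2cnnc(O)n12`, in this assay gives > 48000 nM, again a limit.

Compound 3 thus stands with the other two at the limit, (the limit of > 48000 nM in this assay, at which 3 of the 3 values shown sit). Compound 4, `CC(C)(C)c1ncc2cnnc(O)n12`, differs from it by tert-butyl in place of methoxymethyl on an aromatic carbon. Going by the values given here, the steps that bear on this change, a step that the two limits leave unreadable from compound 1 to compound 3 and a step that the two limits leave unreadable from compound 2 to compound 3, are of unreadable size, as is a step that the two limits leave unreadable from compound 1 to compound 2. Among the compounds with values here, no measured step therefore gives a size or a direction, and the expectation rests on the shared limit alone. Compound 4 is expected to give 60000 nM, within 30000 nM to 200000 nM, most probably reported again as a limit. The step that the limit leaves unreadable from compound 3 to compound 4 is estimated to be none beyond the scatter.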

Compound 4, half-maximal inhibitory concentration: > 48000 nM
Compound 4 ended at the assay's limit; the forecaster's own chance of this, stated with the estimate: 85%; the middle value is on the limit's open side.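

Compound 4 sits at a limit in this assay, as do compound 1, compound 2 and compound 3, so no step among them can be read: the limit of > 48000 nM in this assay, at which 4 of the 4 values shown sit.

The compounds shown leave open whether any substituent at this place on the shared core gives a readable value in this assay.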